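Three Inactive Amides and an Untested Fluorobenzyl Analogue

The compounds below may be only part of what the source reports. "The series", "measured", "known", "first", "only" and "open" are said of these compounds alone.

Measured so far in a functional assay on Huh-7 cells (Homo sapiens) for inhibition, read by MTT assay, with a stated time of 48 h; on this read-out lower numbers stand for stronger inhibition and higher numbers for weaker inhibition:
Compound 1 `O=C(/C=C/c1coc2cc(O)ccc2c1=O)NCc1ccc(F)cc1` gives only the limit > 100000 nM.
Compound 2 `COc1ccc2c(=O)c(/C=C/C(=O)Nc3cccc(Cl)c3)coc2c1` gives only the limit > 100000 nM.
Compound 3 `COc1ccc2c(=O)c(/C=C/C(=O)Nc3ccc(C)cc3)coc2c1` gives only the limit > 100000 nM.

Compound 3 thus stands nowhere in particular: its value is an assay limit, not a number, and the same holds for every value recorded here (the limit of > 100000 nM in this assay, at which 3 of the 3 values shown sit). Among the compounds with values here, the one step between measured neighbours, a step that the two limits leave unreadable from compound 2 to compound 3, is therefore unreadable, since both ends sit at the limit.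

The next compound, compound 4 `COc1ccc2c(=O)c(/C=C/C(=O)NCc3cccc(F)c3)coc2c1`, differs from compound 3 in one place: 3-fluorobenzyl in place of 4-methylphenyl on an amide-type nitrogen. Within the data shown here, no measured step bears directly on this change; compound 1, which also carries a fluorine-bearing benzyl group on its amide nitrogen but a different core, likewise reached only the limit. The step from compound 3 to compound 4 is expected to remain unreadable, with the result most likely another limit.

Compound 4 is estimated at 150000 nM, within 40000 nM to 600000 nM. The estimated step that the limit leaves unreadable from compound 3 to compound 4 is expected to lie within scatter, with no gain in potency anticipated.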

Compound 4, half-maximal inhibitory concentration: 10100 nM
Compound 4: middle estimate off by 15-fold (1.17 log units), on the high side; measured number below the stated range.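

Changing the group on the amide-type nitrogen of the shared core can move the read-out in this assay: replacing 4-methylphenyl with 3-fluorobenzyl gives an at least 9.9-fold lower number from compound 3 to compound 4 (0.99 log units; beyond the scatter), and replacing 3-chlorophenyl with 3-fluorobenzyl gives an at least 9.9-fold lower number from compound 2 to compound 4 (0.99 log units; beyond the scatter), both beyond the usual scatter. Within the data shown here, compound 4 is the first compound here to give a real number rather than an assay limit, so this position is not silent on this core. On these data alone, the true sizes of both steps remain unknown, and each could be larger, because their starting points are limits: the limit of > 100000 nM in this assay, at which 3 of the 4 values shown sit.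

The compounds shown do not separate the effect of the fluorine from that of moving the aromatic ring from the nitrogen to a benzyl group. An unsubstituted benzyl group, a 2-phenylethyl chain or an amine-bearing chain on this nitrogen could help to settle what drives the gain.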